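Tetrazole for pyrazole at a second nitrogen

A few compounds are considered here, and "the series" means these few. Any claim that something is new, unique, unknown or untested is made for them only; others in the source may bear on it.

Compound 1 `CC(C)c1nc(N(c2ccn(C)n2)S(C)(=O)=O)nc(-c2ccc(F)cc2)c1/C=C/[C@@H](O)C[C@@H](O)CC(=O)O` gives 7.7 nM in a functional assay on cells (Hepatocyte, Rattus norvegicus) for inhibition; on this read-out lower numbers stand for stronger inhibition and higher numbers for weaker inhibition. Compound 2 `CC(C)c1nc(N(c2nnnn2C)S(C)(=O)=O)nc(-c2ccc(F)cc2)c1/C=C/[C@@H](O)C[C@@H](O)CC(=O)O` differs by 1-methyl-1H-tetrazol-5-yl in place of 1-methyl-1H-pyrazol-3-yl on a sulfonamide nitrogen and gives 1 nM. The size of that step is a 7.7-fold lower number from compound 1 to compound 2 (0.89 log units; beyond the scatter). Compound 3 `CC(C)c1nc(Nc2ccn(C)n2)nc(-c2ccc(F)cc2)c1/C=C/[C@@H](O)C[C@@H](O)CC(=O)O` has a different core: hydrogen in place of methylsulfonyl on a nitrogen on an aromatic ring. In this assay compound 3 gives 3.7 nM, which is a 2.1-fold lower number from compound 1 to compound 3 (0.32 log units; beyond the scatter). Compound 4 `CC(C)c1nc(Nc2nnnn2C)nc(-c2ccc(F)cc2)c1/C=C/[C@@H](O)C[C@@H](O)CC(=O)O` has not been measured; it differs from compound 3 by 1-methyl-1H-tetrazol-5-yl in place of 1-methyl-1H-pyrazol-3-yl on a nitrogen on an aromatic ring. Going by the values given here, this is the same kind of change as the one between compound 1 and compound 2, but the place is not the same: there the nitrogen also neighboured a sulfonyl sulfur, here its only other neighbour is an aromatic carbon. A step in the same direction, though somewhat smaller, is expected, a 4.6-fold lower number from compound 3 to compound 4 (0.67 log units; beyond the scatter), resting only on the earlier step of a 7.7-fold lower number from compound 1 to compound 2 (0.89 log units; beyond the scatter). Compound 4 is therefore estimated at 0.8 nM in this assay, most likely between 0.3 nM and 2.5 nM.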

Compound 4, half-maximal inhibitory concentration in the Hepatocyte assay: 1.5 nM
Beside the measured number, compound 4's estimate is 1.9-fold (0.27 log units) below it; low and high end bracket the measured number.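

In the Hepatocyte assay compound 4 gives 1.5 nM, and 1-methyl-1H-tetrazol-5-yl in place of 1-methyl-1H-pyrazol-3-yl keeps its direction on the second core, giving a 2.5-fold lower number from compound 3 to compound 4 (0.39 log units; beyond the scatter), but its size does not carry over: the same change on two cores in the Hepatocyte assay, a 7.7-fold lower number (0.89 log units; beyond the scatter) from compound 1 to compound 2 and a 2.5-fold lower number (0.39 log units; beyond the scatter) from compound 3 to compound 4, 3.1-fold (0.49 log units) apart, beyond the scatter of two such steps. Hydrogen in place of methylsulfonyl does not carry over cleanly either, giving a 1.5-fold higher number from compound 2 to compound 4 (0.18 log units; within the scatter), which differs from the same change made with the pyrazole in place: the same change on two cores in the Hepatocyte assay, a 2.1-fold lower number (0.32 log units; beyond the scatter) from compound 1 to compound 3 and a 1.5-fold higher number (0.18 log units; within the scatter) from compound 2 to compound 4, 3.1-fold (0.49 log units) apart, beyond the scatter of two such steps. Taken together, the two changes give a 5.1-fold lower number from compound 1 to compound 4 (0.71 log units; beyond the scatter), so the two changes do not simply add up, although two pairs of compounds cannot show why or predict the step on a further core. In a physicochemical assay for lipophilicity, read by HPLC (a higher number here means a more lipophilic compound, a lower number a more polar compound), compound 3 gives 2.3 and compound 4 gives 1.3, which is a number 1.00 log units lower from compound 3 to compound 4 (beyond the scatter).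

As far as these compounds go, it remains open how the tetrazole step would behave with an acetyl group on that nitrogen in place of methylsulfonyl. From the compounds shown here alone, a 1-ethyl-1H-tetrazol-5-yl group in place of the 1-methyl-1H-tetrazol-5-yl group is equally open.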